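Notes on the amide substituent: compound 3 to compound 4

This account rests on a few compounds, and the source may have more. Where it says the series, first, only, none or still open, it means among the compounds named here.

Three compounds share one core and differ at the carbonyl carbon of the amide or on the core itself. Compound 1 `Cc1nc(NC(=O)c2cccnc2)c2nn(-c3ccccc3)cc2n1` gives 5.3 nM in an assay on CHO cells for displacement of a labelled ligand from adenosine receptor A3 (Homo sapiens), read by scintillation counting, with a stated time of 60 min; on this read-out higher numbers stand for weaker inhibition and lower numbers for stronger inhibition. Compound 3 `Cc1nc(NC(=O)c2ccco2)c2nn(-c3ccccc3)cc2n1` gives 20 nM in this assay, the second highest of the three numbers. Compound 2 `O=C(Nc1nc(-c2ccccc2)nc2cn(-c3ccccc3)nc12)c1ccncc1`, which carries pyridin-4-yl on the carbonyl carbon but a different core, gives 25 nM, within the scatter of compound 3, while compound 1 sits furthest from compound 3. For the measured compounds named here, the only step measured in one place is a 3.8-fold higher number from compound 1 to compound 3 (0.58 log units; beyond the scatter).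

Compound 4 `Cc1nc(NC(=O)c2ccncc2)c2nn(-c3ccccc3)cc2n1` differs from compound 3 by pyridin-4-yl in place of furan-2-yl on a carbonyl carbon. Going by the values given here, the step from compound 1 to compound 3 bears on this change in reverse: putting a pyridyl group back in place of furan-2-yl is expected to lower the number by a similar modest amount, though no measured step shows whether pyridin-4-yl behaves like pyridin-3-yl, and compound 2 offers only its own value on another core. Compound 4 is therefore expected to show a 2.5-fold lower number from compound 3 to compound 4 (0.40 log units; beyond the scatter). The estimate for compound 4 is 8 nM, with a range from 3 nM to 25 nM.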

Compound 4, inhibition constant: 5.2 nM
Compound 4: the middle estimate sits 1.5-fold (0.19 log units) above what was measured; the range from low to high includes it.
By their numbers in this assay, from the lowest: compounds 4 and 1 (each within the scatter of the next); then compounds 3 and 2 (each within the scatter of the next).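

In this assay the swap of furan-2-yl for pyridin-4-yl on the carbonyl carbon gives a 3.8-fold lower number from compound 3 to compound 4 (0.59 log units; beyond the scatter) and so mirrors in size the earlier 3.8-fold higher number from compound 1 to compound 3 (0.58 log units; beyond the scatter) in the opposite direction. For the compounds shown here, the two pyridyl groups cannot be told apart at this position, as the comparison shows a 1.0-fold lower number from compound 1 to compound 4 (0.01 log units; within the scatter) and leaves furan-2-yl as the only group here with a number beyond the scatter of both. Going by these compounds alone, with the pyridin-4-yl carbonyl held fixed, the other varied place also registers for the first time, since methyl in place of phenyl on an aromatic carbon gives a 4.8-fold lower number from compound 2 to compound 4 (0.68 log units; beyond the scatter) and this change matters at least as much as the one at the amide. No measurement at hand accounts for any of these steps.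

From the compounds shown here alone, it remains open whether the match between the two pyridyl groups extends to pyridin-2-yl, or whether a saturated piperidine ring or a simple alkyl chain on the carbonyl carbon would stay with them or with furan-2-yl. Also open, going by these compounds, is whether ethyl or an amine on the aromatic carbon would follow methyl or phenyl, and whether that step holds with furan-2-yl on the carbonyl carbon.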